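Amide aryl variation on the shared core: compound 3

This account rests on a few compounds, and the source may have more. Where it says the series, first, only, none or still open, it means among the compounds named here.

Measured so far in this assay:
compound 1, `CCn1cc(C(=O)Nc2ccccc2O)c(=O)c2cc(F)c(N3CCNC(C)C3)c(F)c21`, 7430 nM
compound 2, `CCn1cc(C(=O)Nc2ccc(C)c([N+](=O)[O-])c2)c(=O)c2cc(F)c(N3CCNC(C)C3)c(F)c21`, 4200 nM

In a functional assay on MDA-MB-231 cells (Homo sapiens) for cytotoxicity, read by MTT assay (on this read-out higher numbers stand for weaker inhibition and lower numbers for stronger inhibition), compound 1 gives 7430 nM, and compound 2 gives 4200 nM. Among the compounds with values here, the one step between them, a 1.8-fold lower number from compound 1 to compound 2 (0.25 log units; within the scatter), is the only comparison available, and it falls within the scatter; compound 2 and compound 1 therefore sit at essentially the same level, and neither can be placed ahead of the other.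

Compound 3, `CCn1cc(C(=O)Nc2cc([N+](=O)[O-])ccc2F)c(=O)c2cc(F)c(N3CCNC(C)C3)c(F)c21`, differs from compound 2 at the aryl group on the amide-type nitrogen: 2-fluoro-5-nitrophenyl in place of 4-methyl-3-nitrophenyl on an amide-type nitrogen. Within the data shown here, the only step that bears on this kind of change is the one from compound 1 to compound 2, which replaced one aryl group on the same nitrogen with another and stayed within the scatter. On that basis, no step beyond the scatter is expected for compound 3 in this assay, and the expected step is a 1.1-fold higher number from compound 2 to compound 3 (0.03 log units; within the scatter). Compound 3 is estimated at 4500 nM, with a range of 1800 nM to 11000 nM.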

Compound 3, half-maximal inhibitory concentration: 6900 nM
The estimate for compound 3 lay 1.5-fold (0.19 log units) below the measured number, within the range that was stated.
By their numbers in this assay, from the lowest: compounds 2, 3 and 1 (each within the scatter of the next).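

In this assay, replacing 4-methyl-3-nitrophenyl with 2-fluoro-5-nitrophenyl on the amide-type nitrogen gives a 1.6-fold higher number from compound 2 to compound 3 (0.22 log units; within the scatter) and replacing 2-hydroxyphenyl with the same group gives a 1.1-fold lower number from compound 1 to compound 3 (0.03 log units; within the scatter). The three aryl groups compared at this position therefore sit at one level, and this now holds for two changes into 2-fluoro-5-nitrophenyl as well as for the earlier change between the other two groups. No measured evidence bears on why these replacements leave the number within the scatter.

As far as these compounds go, it remains open whether any group on this nitrogen can move the number beyond the scatter, for example a cyclohexyl group, a longer alkyl chain, or a phenyl ring carrying a carboxylic acid or an amine. The compounds shown also leave open whether changes elsewhere on the shared core would matter more.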